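Turning One Stereocentre of Compound 2

This account rests on a few compounds, and the source may have more. Where it says the series, first, only, none or still open, it means among the compounds named here.

Within the data shown here, in a functional assay on A549 cells (Homo sapiens) for inhibition, read by MTT assay, with a stated time of 72 h (on this read-out higher numbers stand for weaker inhibition and lower numbers for stronger inhibition), compound 1 `CC1=NN(c2ccccc2)C(=O)[C@]12C(=O)C=CC[C@H]2c1cccc(C)c1` gives 13100 nM, while compound 2 `CC1=NN(c2ccccc2)C(=O)[C@@]12C(=O)C=CC[C@@H]2c1cccc(C)c1` gives 4510 nM, the lower of the two numbers so far. Among the measured compounds shown here, the single measured step is a 2.9-fold lower number from compound 1 to compound 2 (0.46 log units; beyond the scatter). This modest gap can be put down to the fact that compounds 1 and 2 differ only in the configuration as drawn, and in it all stereocentres are inverted.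

Compound 3 `CC1=NN(c2ccccc2)C(=O)[C@]12C(=O)C=CC[C@@H]2c1cccc(C)c1` has not yet been measured. Its relation to compound 2 is this: the two compounds have the same atoms and bonds and differ only in configuration as drawn: 1 of 2 stereo elements differ; a stereocentre at a saturated ring carbon is drawn R in compound 2 and S in compound 3. For the measured compounds named here, nothing leaves and nothing enters, so the one measured step is the only guide, and it concerns a change of configuration at both stereo elements rather than at one. A modest shift in this assay is therefore expected, of no greater size than that step, though its direction is uncertain. Compound 2 already holds the lower number of the pair, so a move towards a higher number seems the likelier outcome. The expected change is a 1.8-fold higher number from compound 2 to compound 3 (0.25 log units; within the scatter). Compound 3 is estimated at 8000 nM, with an expected range from 2500 nM to 22000 nM.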

Compound 3, half-maximal inhibitory concentration: 4770 nM
Compound 3: the middle estimate sits 1.7-fold (0.22 log units) above what was measured; the measured number falls inside the stated range.
By their numbers in this assay, from the lowest: compounds 2 and 3 (each within the scatter of the next); then compound 1.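

The new compound separates the two stereocentres, which the mirror-image pair could not do, since both were inverted at once in that step. In this assay the stereocentre that differs between the next pair gives a 1.1-fold higher number from compound 2 to compound 3 (0.02 log units; within the scatter), so at this position the configuration as drawn cannot be distinguished by this read-out. The other stereocentre, taken alone, gives a 2.7-fold lower number from compound 1 to compound 3 (0.44 log units; beyond the scatter), a step beyond the scatter that can be put down to configuration, as nothing else changes: the fact that compounds 1 and 3 differ only in the configuration as drawn

Among these three compounds, then, compound 1 stands apart while compound 2 and compound 3 sit within the scatter of each other, although the pattern rests on a single series with one substituent set and a single cell read-out. The compounds shown leave open how the remaining combination of the two stereocentres would read, and whether the same dependence on configuration would hold if a methoxy group or a carboxylic acid took the place of the methyl group on the shared core.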